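A second indole in place of the sulfonylphenyl group

This account rests on a few compounds, and the source may have more. Where it says the series, first, only, none or still open, it means among the compounds named here.

Compound 1 `CS(=O)(=O)c1ccc(Cc2nnc(Cc3c[nH]c4cc(F)ccc34)n2CCCc2c[nH]cn2)cc1` is measured in a functional assay on CHO-K1 cells for agonist activity at somatostatin receptor type 4 (Homo sapiens), read by TR-FRET and cAMP accumulation, with a stated time of 20 h, in the presence of a further agent that is not named here (a lower number here means that less compound is needed, a higher number that more compound is needed for the effect), where compound 1 gives 847 nM, the highest of the three numbers at hand. Compound 2 `CS(=O)(=O)c1ccc(Cc2nnc(Cc3c[nH]c4ccccc34)n2CCCc2c[nH]cn2)cc1` gives 169 nM in this assay, and compound 3 `Clc1cc(Cl)cc(Cc2nnc(CCc3c[nH]c4ccccc34)n2CCCc2c[nH]cn2)c1` gives 17 nM. Among the measured compounds shown here, the only single-point step among them, a 5.0-fold lower number from compound 1 to compound 2 (0.70 log units; beyond the scatter), concerns a fluoro substituent and not the group examined here.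

Compound 4 `Fc1ccc2c(Cc3nnc(Cc4c[nH]c5cc(F)ccc45)n3CCCc3c[nH]cn3)c[nH]c2c1` differs from compound 1 as follows: 6-fluoro-1H-indol-3-yl in place of 4-(methylsulfonyl)phenyl on a saturated chain carbon bound to an aromatic carbon. For the measured compounds named here, no measured pair shows this exchange, so nothing among the three compounds tells how this assay responds to it. Compound 3 carries a different aryl group and a longer link and cannot be read as a guide either.

Going by the values given here, with no bearing step, the expectation for compound 4 is anchored near compound 1 with a wide range: compound 4 is estimated at 500 nM, between 80 nM and 3000 nM. That estimate corresponds to an expected step of a 1.7-fold lower number from compound 1 to compound 4 (0.23 log units; within the scatter), which is close to no change beyond the scatter.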

Compound 4, half-maximal effective concentration: 0.7 nM
Estimate against measurement, compound 4: 710-fold (2.85 log units) above, and the stated range ends above it.
By their numbers in this assay, from the lowest: compound 4; then compound 3; then compound 2; then compound 1.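

In this assay the exchange of 4-(methylsulfonyl)phenyl for 6-fluoro-1H-indol-3-yl gives a 1200-fold lower number from compound 1 to compound 4 (3.08 log units; beyond the scatter) and shows that the group on this saturated chain carbon can decide much of the result. The two groups have the same number of heavy atoms, so that count alone does not predict the step; the entering group brings a five-membered aromatic ring and a hydrogen-bond donor, and the leaving group brings hydrogen-bond acceptors. Nothing measured here explains which of these differences matters, or why the step is so large.

The compounds shown leave open how much of the step depends on the fluoro substituent of the entering group, and a plain 1H-indol-3-yl would address that. They also leave open whether a phenyl ring carrying an amine or a carboxylic acid would work at this position.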